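Adding a Methyl to a Bis-Aziridinyl Quinone Side Chain

This account rests on a few compounds, and the source may have more. Where it says the series, first, only, none or still open, it means among the compounds named here.

Of the compounds shown here, three have been tested in a functional assay on L1210 cells (Mus musculus), with a stated time of 1 days; on this read-out higher numbers stand for higher potency (the scale is a negative logarithm) and lower numbers for lower potency. Compound 1 `CCCC1=C(N2CC2)C(=O)C(C(COC(N)=O)OC)=C(N2CC2)C1=O` gives 4.64, compound 2 `CCC1=C(N2CC2)C(=O)C(C(COC(N)=O)OC)=C(N2CC2)C1=O` gives 4.92, and compound 3 `CC1=C(N2CC2)C(=O)C(C(C)COC(N)=O)=C(N2CC2)C1=O` gives 5.31. Compound 3 and compound 2 share a related core, but the difference between the two cores is not broken down here.

Compounds 1 and 2 differ in one place: methyl in place of hydrogen on a saturated chain carbon, two bonds along the chain from a double-bonded ring carbon. This change produced a number 0.28 log units lower from compound 2 to compound 1 (within the scatter).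

Compound 4 `CCC(COC(N)=O)C1=C(N2CC2)C(=O)C(C)=C(N2CC2)C1=O` has not yet been measured. It differs from compound 3 by the same change: methyl in place of hydrogen on a saturated chain carbon, two bonds along the chain from a double-bonded ring carbon. Cut one bond further out, the earlier change also reads ethyl to propyl, so the surroundings of the change are not identical even though the place is described in the same words.

On the basis of the earlier change, which left the number essentially where it was, compound 4 is expected to stay close to compound 3, with a step of a number 0.21 log units lower from compound 3 to compound 4 (within the scatter). Compound 4 is therefore estimated at 5.1, in a band from 4.6 to 5.6 in this assay.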

Compound 4, logarithm of the reciprocal of the active concentration, log(1/C): 5.2
For compound 4 the middle estimate is 0.10 log units below the measured one, within the range that was stated.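

In this assay, putting methyl in place of hydrogen gave a number 0.11 log units lower from compound 3 to compound 4 (within the scatter), so compound 3 and compound 4 cannot be told apart on this read-out. Set beside the earlier case, the two steps agree: the same change on two cores in this assay, a number 0.28 log units lower (within the scatter) from compound 2 to compound 1 and a number 0.11 log units lower (within the scatter) from compound 3 to compound 4, 0.17 log units apart, within the scatter of two such steps. This shows that on these two cores the change left the number within the usual scatter both times, but two small steps from two pairs of compounds do not establish a rule for the whole series, and they do not show why the number held or what would happen on a more different core.

The compounds shown leave open whether a longer chain such as butyl, or a different kind of group such as an amine or a carboxylic acid, at this same place would also keep the number within the scatter. They also leave open whether the same small step would appear on other cells.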